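This account rests on a few compounds, and the source may have more. Where it says the series, first, only, none or still open, it means among the compounds named here.

Measured so far in a functional assay on HL-60 cells (Homo sapiens) for antiproliferative activity, read by MTT assay, with a stated time of 48 h; a lower number here means a stronger inhibitor, a higher number a weaker inhibitor:
- compound 1 `CC(=O)O[C@@H]1/C=C/[C@@](C)(CCC=C(C)C)C/C=C(/CO)C(=O)/C=C/[C@@]1(C)O`: 5050 nM
- compound 2 `CC(C)=CCC[C@]1(C)/C=C/[C@@H](OC(=O)C(C)C)[C@](C)(O)/C=C/C(=O)/C(CO)=C\C1`: 4000 nM
- compound 3 `CC(C)=CCC[C@]1(C)/C=C/[C@@H](OC(=O)c2ccccc2)[C@](C)(O)/C=C/C(=O)/C(CO)=C\C1`: 22600 nM

Compound 3, at 22600 nM, has the highest number of the three, and its gaps to both of the others lie beyond the scatter. The next compound, compound 4 `COCO[C@@H]1/C=C/[C@@](C)(CCC=C(C)C)C/C=C(/CO)C(=O)/C=C/[C@@]1(C)O`, keeps the shared core but carries methoxymethyl in place of benzoyl on an oxygen on a saturated carbon.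

Within the data shown here, three measured steps bear on this change, and all of them alter the group on a carbonyl carbon. Isopropyl in place of methyl gave a 1.3-fold lower number from compound 1 to compound 2 (0.10 log units; within the scatter), which is no real change. Phenyl in place of methyl gave a 4.5-fold higher number from compound 1 to compound 3 (0.65 log units; beyond the scatter), and phenyl in place of isopropyl gave a 5.7-fold higher number from compound 2 to compound 3 (0.75 log units; beyond the scatter). Among these three compounds, then, only the one with the phenyl stands apart.

Compound 4 has no such ring, so it is expected to fall back towards compound 1 and compound 2. Among the measured compounds shown here, no measured compound carries methoxymethyl, however, so this comparison is loose and the range is wide. A modest step towards a lower number is therefore expected in this assay, similar in size to the two phenyl steps but opposite in direction. The estimated change is a 3.8-fold lower number from compound 3 to compound 4 (0.58 log units; beyond the scatter). The expected value for compound 4 is 6000 nM, with an estimated range of 2500 nM to 15000 nM.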

Compound 4, half-maximal inhibitory concentration: > 40000 nM
Compound 4: only a limit was reported; the forecaster's own chance of this, stated with the estimate: 3%; middle value at least 6.6-fold (0.82 log units) away from the limit.
By their numbers in this assay, from the lowest: compounds 2 and 1 (each within the scatter of the next); then compound 3. At a limit, above all of these: compound 4.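

In this assay compound 4 is reported only as a limit, not as a number: the limit of > 40000 nM in this assay, at which 1 of the 4 values shown sits.

Even so, moving from an ester to methoxymethyl at this oxygen on a saturated carbon gives an at least 7.9-fold higher number from compound 1 to compound 4 (0.89 log units; beyond the scatter) and an at least 10-fold higher number from compound 2 to compound 4 (1.00 log units; beyond the scatter), and both floors lie beyond the scatter, while an at least 1.7-fold higher number from compound 3 to compound 4 (0.24 log units; that floor lies within the scatter) has a floor within the scatter, so the order of compound 3 and compound 4 cannot be fixed. The earlier compounds shown here varied only the group on the carbonyl carbon, and among them only the phenyl of compound 3 stood apart; compound 4 shows that losing the aromatic ring does not by itself bring the number back to the level of compound 1 and compound 2, since methoxymethyl, with no ring and no carbonyl, also lies well above them.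

The compounds shown do not separate the effect of losing the carbonyl from that of methoxymethyl itself, and a plain methyl ether, a carbamate or the free hydroxyl at this oxygen would speak to that. On these data alone, how far the number of compound 4 really lies beyond its limit also stays open.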